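The source may report more compounds than this note shows. Statements on the series, on what has been measured and on what is new or still open speak of the compounds shown alone.

Measured compounds:
compound 1, `CCCS(=O)(=O)N1CCC(CNC(=O)c2c(F)ccc(Cl)c2F)(C(=O)N2CCOCC2)CC1`: 42.8 nM
compound 2, `CCCS(=O)(=O)N1CCC(CNC(=O)c2ccc(Cl)cc2Cl)(C(=O)NCC)CC1`: "not determined" (no result reported)
compound 3, `CCCS(=O)(=O)N1CCC(CNC(=O)c2ccccc2OC(F)(F)F)(C(=O)N2CCOCC2)CC1`: "not determined" (no result reported)

For the measured compounds named here, in an assay on isolated protein for inhibition of sodium- and chloride-dependent glycine transporter 1 (Mus musculus) (on this read-out lower numbers stand for stronger inhibition and higher numbers for weaker inhibition), compound 1 gives 42.8 nM and is the only compound of the set with a number; compound 2 gives "not determined" (no result reported) and compound 3 gives "not determined" (no result reported), so nothing can be said of how they compare. The step from compound 1 to compound 4, `CCCS(=O)(=O)N1CCC(CNC(=O)c2ccccc2Cl)(C(=O)N2CCOCC2)CC1`, changes one group: 2-chlorophenyl in place of 3-chloro-2,6-difluorophenyl on a carbonyl carbon. Going by the values given here, no step between two measured compounds is available to guide the expectation, so the size is uncertain. The expectation for compound 4 is a modest weakening, with the step of a 2.6-fold higher number from compound 1 to compound 4 (0.41 log units; beyond the scatter) reaching somewhat beyond the usual scatter. Compound 4 is therefore estimated at 110 nM, within a range from 30 nM to 400 nM.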

Compound 4, half-maximal inhibitory concentration: 95.3 nM
Compound 4: the middle estimate sits 1.2-fold (0.06 log units) above what was measured; the range from low to high includes it.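

In this assay, placing 2-chlorophenyl instead of 3-chloro-2,6-difluorophenyl on this carbonyl carbon gives a 2.2-fold higher number from compound 1 to compound 4 (0.35 log units; beyond the scatter), so inhibition weakens modestly but is not lost. Because the groups differ in both their fluorine and chlorine substitution, this single step cannot show which difference matters. No supporting measurement explains the shift. Steps involving compound 2 and compound 3 cannot be read, as neither has a result. From the compounds shown here alone, how an unsubstituted phenyl or a nitrile-bearing phenyl would behave on this carbonyl carbon remains open.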